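The compounds below may be only part of what the source reports. "The series", "measured", "known", "first", "only" and "open" are said of these compounds alone.

Compound 1 `CC(C)(C)C(=O)NCCCCN1CCN(c2ccc(Cl)cc2)CC1` carries a chlorine on its aromatic ring, and in an assay on HEK293 cells for binding affinity to D(4) dopamine receptor (Homo sapiens), read by radioligand binding (a higher number here means a weaker inhibitor, a lower number a stronger inhibitor), compound 1 gives 12.6 nM. Among the measured compounds shown here, its only measured partner is compound 2 `CC(C)(C)C(=O)NCCCCN1CCN(c2ccc(F)cc2)CC1`, which differs solely in having fluorine in place of that chlorine; in this assay compound 2 gives 126 nM. For the measured compounds named here, the single known step is a 10-fold higher number from compound 1 to compound 2 (1.00 log units; beyond the scatter), so compound 1 stands as the lower of the two numbers, which here means the stronger binder.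

Compound 3 `CCC(C)(C)C(=O)NCCCCN1CCN(c2ccc(Cl)cc2)CC1` is not yet measured. It differs from compound 1 by methyl in place of hydrogen on a saturated chain carbon, two bonds along the chain from a carbonyl carbon, that is, a small extension on the saturated end of the amide rather than any change at the aromatic ring. Going by the values given here, the one measured step, between compound 1 and compound 2, concerns the ring halogen and does not speak to a change on the amide side; there is no measured pair that isolates this kind of chain growth. With nothing to indicate a shift in either direction, the expectation for compound 3 is a step of a 1.0-fold higher number from compound 1 to compound 3 (0.01 log units; within the scatter), within the usual scatter. Compound 3 is therefore estimated at 13 nM in this assay, expected to fall between 4 nM and 40 nM.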

Compound 3, inhibition constant: 15.9 nM
The estimate for compound 3 lay 1.2-fold (0.09 log units) below the measured number; the measured number falls inside the stated range.
By their numbers in this assay, from the lowest: compounds 1 and 3 (each within the scatter of the next); then compound 2.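

Replacing a hydrogen with methyl turns the tert-butyl group into 1,1-dimethylpropyl, and in this assay this gives a 1.3-fold higher number from compound 1 to compound 3 (0.10 log units; within the scatter) with the ring chlorine kept in place. Among the compounds shown here, this is the first measured change at the saturated end of the amide, and it shows that this position accepts one added methyl with no change beyond the usual scatter of the assay. The ring halogen change behaves differently, since a 10-fold higher number from compound 1 to compound 2 (1.00 log units; beyond the scatter) is a step beyond the scatter, so in these three compounds the swap on the aromatic ring matters more than the added methyl on the chain, and no measurement shown here explains either result.

One added methyl says little about larger changes at this position, so a longer chain such as n-hexyl, a ring such as cyclohexyl, or an amine or a carboxylic acid on that carbon could give a very different number. As far as these compounds go, it also remains open whether the same added methyl would leave the number as little changed on the fluoro compound, compound 2, as it does on the chloro compound, compound 1.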